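A few compounds are considered here, and "the series" means these few. Any claim that something is new, unique, unknown or untested is made for them only; others in the source may bear on it.

Working notes on the series, read in an ADME assay on microsomes from liver (Rattus norvegicus) for metabolic stability, read by LC-MS, using NADPH, with stated times of 10 min and 45 min, tested at 0.3 mM; a higher number here means faster removal of the compound, a lower number slower removal. Compound 1 `Fc1cncc(-n2ncc3cc(F)ccc32)c1` gives 85 mL/min/kg. Compound 2 `CC(C)(O)c1cncc(-n2ncc3ccccc32)c1` gives < 20 mL/min/kg, and this is a limit of the assay, not a number. Compound 2 therefore stands at the limit of the scale: the limit of < 20 mL/min/kg in this assay, at which 1 of the 2 values shown sits. Among the measured compounds shown here, no measured pair differs in one place only, so the data offer no direct size for a single change.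

The next compound is compound 3 `CC(C)(O)c1cncc(-n2ncc3cccc(F)c32)c1`, which differs from compound 2 by fluoro in place of hydrogen on an aromatic carbon. In words, this is fluoro in place of hydrogen on an aromatic carbon. The estimated step of a number no lower from compound 2 to compound 3 (the limit leaves the size open) is expected to stay within the scatter of this assay, with no direction expected beyond it. A report of only a limit is also expected to be quite possible. For compound 3 the estimated clearance is 20 mL/min/kg, with an expected range of 10 mL/min/kg to 40 mL/min/kg.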

Compound 3, clearance: < 20 mL/min/kg
Compound 3: a limit, no number; the forecaster's own chance of this, stated with the estimate: 55%; the middle value lies on the limit itself.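

Compound 2 and compound 3 each give only a limit, not a number, so no step can be read between them for fluoro in place of hydrogen on an aromatic carbon. The compounds shown leave open the size and direction of this change in clearance.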